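The source may hold more compounds than are shown below. What is called first, only, known or untested is meant among the compounds shown, and "the series" means these compounds.

Working notes on a small amide series in an ADME assay on HEK293 cells (Homo sapiens) for cytotoxicity, read by MTT assay, with a stated time of 48 h; on this read-out lower numbers stand for stronger inhibition and higher numbers for weaker inhibition. Compound 1 `COc1cc(NC(=O)c2cccc(C(F)(F)F)c2)ccc1NS(=O)(=O)C(F)(F)F` carries a ((trifluoromethyl)sulfonyl)amino group together with a methoxy substituent. In this assay compound 1 reaches only > 250000 nM, which is a limit of the assay and not a number. Compound 2 `CCS(=O)(=O)Nc1ccc(NC(=O)c2cccc(C(F)(F)F)c2)cc1Cl` carries an (ethylsulfonyl)amino group together with a chloro substituent; in this assay compound 2 gives 159000 nM. Compound 2 therefore stands at the only number shown, the other value recorded being (the limit of > 250000 nM in this assay, at which 1 of the 2 values shown sits). Within the data shown here, no step between measured compounds is available, so nothing can be said about the size of any change so far. Compound 3 `O=C(Nc1ccc(NS(=O)(=O)C(F)(F)F)c(Cl)c1)c1cccc(C(F)(F)F)c1` is still to be measured. The change trifluoromethyl in place of ethyl on a sulfonyl sulfur takes compound 2 to compound 3. The two values shown both lie at weak inhibition, and no step beyond the usual scatter is expected from compound 2 to compound 3, with a real chance that compound 3 also returns only a limit. Compound 3 is estimated at 200000 nM, with a range from 90000 nM to 300000 nM. The expected step from compound 2 to compound 3 is a 1.3-fold higher number from compound 2 to compound 3 (0.10 log units; within the scatter).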

Compound 3, half-maximal inhibitory concentration: 210000 nM
Beside the measured number, compound 3's estimate is 1.1-fold (0.02 log units) below it; the measured number falls inside the stated range.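

In this assay the sulfonyl sulfur gives its first readable step, with trifluoromethyl in place of ethyl on a sulfonyl sulfur: the change reads as a 1.3-fold higher number from compound 2 to compound 3 (0.12 log units; within the scatter), so this exchange does not separate the pair. A second comparison now exists on an aromatic carbon, with chloro in place of methoxy, and it reads as an at least 1.1-fold lower number from compound 1 to compound 3 (0.07 log units; that floor lies within the scatter). That step is only a floor, and its true size cannot be read because compound 1 stands at a limit of the assay and not at a number: the limit of > 250000 nM in this assay, at which 1 of the 3 values shown sits.

Among these compounds, still open is whether any other group on the sulfonyl sulfur, such as a longer chain or a phenyl ring, would move the number beyond the scatter, since ethyl and trifluoromethyl alone give no such step here. Also open, going by these compounds, is how the number responds on the aromatic carbon to a group other than chloro or methoxy, such as an amine or a carboxylic acid, and whether such a group would give a step that can be read in full.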